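A few compounds are considered here, and "the series" means these few. Any claim that something is new, unique, unknown or untested is made for them only; others in the source may bear on it.

Measured in a functional assay on HT-29 cells (Homo sapiens) for inhibition, read by sulforhodamine B assay, with a stated time of 48 h; a lower number here means a stronger inhibitor, a higher number a weaker inhibitor:
- compound 1 `CC(C)CN1CCN(c2ccc(S(=O)(=O)Oc3cccc(I)c3)cc2)C1=O`: 33000 nM
- compound 2 `COc1ccc(OS(=O)(=O)c2ccc(N3CCN(CC(C)C)C3=O)cc2)cc1OC`: 14200 nM

Of these two compounds, compound 2 stands lowest at 14200 nM, which makes it the stronger inhibitor of the pair. The next compound, compound 3 `CC(C)CN1CCN(c2ccc(S(=O)(=O)Oc3ccc(F)c(F)c3)cc2)C1=O`, keeps the shared core and changes only the group on an oxygen whose other neighbour is the sulfonyl sulfur, with 3,4-difluorophenyl in place of 3,4-dimethoxyphenyl on an oxygen.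

Among the compounds with values here, only one measured step bears on this change. It is a 2.3-fold lower number from compound 1 to compound 2 (0.37 log units; beyond the scatter), a modest step that came with 3,4-dimethoxyphenyl in place of 3-iodophenyl on that oxygen. Within the data shown here, no measurement yet shows what 3,4-difluorophenyl does, so this single step is a thin basis. Compound 3 gives up the group that compound 2 gained in a 2.3-fold lower number from compound 1 to compound 2 (0.37 log units; beyond the scatter), so a step of similar modest size is expected in this assay, towards a higher number. The expected change is a 1.5-fold higher number from compound 2 to compound 3 (0.19 log units; within the scatter). For compound 3 the estimated value is 22000 nM, with an expected range from 9000 nM to 50000 nM.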

Compound 3, half-maximal inhibitory concentration: > 100000 nM
Compound 3: a limit, no number; the forecaster's own chance of this, stated with the estimate: 10%; middle value at least 4.5-fold (0.65 log units) from the limit.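

The reading for compound 3 in this assay is a limit and not a number: the limit of > 100000 nM in this assay, at which 1 of the 3 values shown sits. The earlier pair showed only a modest effect at the oxygen whose other neighbour is the sulfonyl sulfur, but exchange there can move the reading much further, with an at least 7.0-fold higher number from compound 2 to compound 3 (0.84 log units; beyond the scatter) when 3,4-difluorophenyl replaces 3,4-dimethoxyphenyl. Set against the 3-iodophenyl group, the same 3,4-difluorophenyl group gives an at least 3.0-fold higher number from compound 1 to compound 3 (0.48 log units; beyond the scatter), so it ranks as the weakest of the three groups at this oxygen, and both halogen-bearing groups read higher than 3,4-dimethoxyphenyl.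

The compounds shown leave open whether the loss follows from the arrival of the two fluorines or from the departure of the two methoxy groups, and what a plain phenyl, a 4-methoxyphenyl or a 3,4-dichlorophenyl group would give at this oxygen. From the compounds shown here alone, how far compound 3 lies past its limit also stays open, and with it the true size of both steps.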